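The source may hold more compounds than are shown below. What is called first, only, known or untested is meant among the compounds shown, and "the series" means these compounds.

Compound 1 `CC1=CC[C@H](C(C)(C)NC(=S)N/N=C/c2ccc(O)cc2)CC1`: 600 nM
Compound 2 `CC1=CC[C@H](C(C)(C)NC(=S)N/N=C/c2ccc(F)cc2)CC1`: < 40 nM

Two measured compounds share one core and differ only in the group carried on the aromatic ring. In a functional assay on PC-3 cells (Homo sapiens) for inhibition, read by sulforhodamine B assay, with a stated time of 48 h (on this read-out higher numbers stand for weaker inhibition of growth and lower numbers for stronger inhibition of growth), compound 1 gives 600 nM. Compound 2 reaches only a limit of the assay, < 40 nM, so no exact number is known for it. Compound 1 therefore stands as the only real number shown; the other value is a limit. Among the compounds with values here, the single measured step, an at least 15-fold lower number from compound 1 to compound 2 (1.17 log units; beyond the scatter), is large, but its true size is open, since it rests on (the limit of < 40 nM in this assay, at which 1 of the 2 values shown sits).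

The compound not yet measured, compound 3 `COc1cc(/C=N/NC(=S)NC(C)(C)[C@H]2CC=C(C)CC2)ccc1O`, differs from compound 1 by methoxy in place of hydrogen on an aromatic carbon. The hydroxy group of compound 1 stays in place. Within the data shown here, no measured step bears directly on this change: the step from compound 1 to compound 2 exchanges the hydroxy for fluoro, whereas here a methoxy is added and the hydroxy remains. Without a comparable step, no change beyond the scatter is expected, and compound 3 is expected to give 500 nM, between 150 nM and 2000 nM. That estimate means an expected step of a 1.2-fold lower number from compound 1 to compound 3 (0.08 log units; within the scatter).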

Compound 3, concentration for 50% growth inhibition: 300 nM
Compound 3: middle estimate off by 1.7-fold (0.22 log units), on the high side, and the stated range covers the measured number.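

Within the data shown here, the methoxy group enters on an aromatic carbon ortho to a hydroxy group, so this is the first look at a ring place other than the one that carries the hydroxy group in compound 1. In this assay the change gives a 2.0-fold lower number from compound 1 to compound 3 (0.30 log units; within the scatter), so the two compounds cannot be told apart on this read-out. Growth inhibition at this level is therefore kept with a methoxy at this place while the hydroxy stays, whereas the earlier step showed only what follows when the hydroxy itself is exchanged.

As far as these compounds go, a single methoxy says little about other groups on the same carbon, so it remains open whether an ethoxy, an amine or a carboxylic acid there would give a number like that of compound 1, and whether methoxy would behave the same way with fluoro in place of the hydroxy. The true size of the step to compound 2 also stays open, as its value is a limit and not a number: the limit of < 40 nM in this assay, at which 1 of the 3 values shown sits.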